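Notes on a bromopyrazolopyrimidine series: GCN2 inhibition

A few compounds are considered here, and "the series" means these few. Any claim that something is new, unique, unknown or untested is made for them only; others in the source may bear on it.

Measured compounds:
compound 1 `Brc1nn(-c2ccc3ncccc3c2)c2nc(Nc3cnn(C4CCNCC4)c3)ncc12` — 610 nM
compound 2 `COCCNC(=O)CCNc1ncc2c(Br)nn(-c3ccc4ncccc4c3)c2n1` — "nd" (no result reported)

In an assay on SK-OV-3 cells for inhibition of eIF-2-alpha kinase GCN2 (Homo sapiens) (a higher number here means a weaker inhibitor, a lower number a stronger inhibitor), compound 1 gives 610 nM. In this assay compound 2 gives "nd" (no result reported), that is, no number, so it stands nowhere on the scale shown; it serves only as the structural starting point. Compound 3 `CNC(=O)[C@@H]1CC[C@@H](Nc2ncc3c(Br)nn(-c4ccc5ncccc5c4)c3n2)C1` is not yet measured. It differs from compound 2 by a group of 9 heavy atoms (7 carbon, 1 nitrogen, 1 oxygen; one five-membered non-aromatic ring of carbon only) in place of a group of 9 heavy atoms (6 carbon, 1 nitrogen, 2 oxygen; no ring), on a nitrogen on an aromatic ring. Within the data shown here, with no value for compound 2 and no step between measured compounds, the size and direction of this change cannot be judged from the data. For compound 3 the estimate rests on compound 1 alone, which gives 610 nM. Compound 3 is expected to show 800 nM, within 150 nM to 4000 nM.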

Compound 3, half-maximal inhibitory concentration: 25 nM
Estimate against measurement, compound 3: 32-fold (1.51 log units) above; measured number outside the range, below it.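

Among these compounds, compound 2 carries no number, and no step from it to compound 3 can be read. As far as these compounds go, what the exchange of the 2-((2-methoxyethyl)carbamoyl)ethyl group for the five-membered ring group does to inhibition stays open. No evidence bears on this result.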